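The compounds below may be only part of what the source reports. "The series", "measured", "known", "first", "only" and "open" are said of these compounds alone.

Compound 2 `O=C(NCCCCl)Nc1ccc(S(=O)(=O)Oc2ccc(O)cc2)cc1` carries a 4-hydroxyphenoxy group on the sulfonyl sulfur of the shared core. In a functional assay on HT-29 cells (Homo sapiens) for cytotoxicity, read by sulforhodamine B assay, with a stated time of 48 h (on this read-out lower numbers stand for stronger inhibition and higher numbers for weaker inhibition), compound 2 gives 50000 nM, the second highest of the three numbers recorded here. Compound 1 `CCc1ccccc1OS(=O)(=O)c1ccc(NC(=O)NCCCCl)cc1` gives 15000 nM, and the step of a 3.3-fold higher number from compound 1 to compound 2 (0.52 log units; beyond the scatter) lies beyond the scatter. Compound 3 `Cc1ccccc1NS(=O)(=O)c1ccc(NC(=O)NCCCCl)cc1` gives 64000 nM, and the step of a 1.3-fold higher number from compound 2 to compound 3 (0.11 log units; within the scatter) stays within the scatter. Compound 4 `CCNC(=O)Nc1ccc(S(=O)(=O)Oc2ccc(O)cc2)cc1` differs from compound 2 by hydrogen in place of chloromethyl on a saturated chain carbon, two bonds along the chain from an amide-type nitrogen. Both measured steps alter the group on the sulfonyl sulfur; neither touches the urea chain, which is the same in all three measured compounds. Among the measured compounds shown here, no measured step therefore bears on this change, and the data give no guide to its size or direction. On these grounds compound 4 is expected to give 100000 nM, within a wide range from 25000 nM to 400000 nM. The estimated step of a 2.0-fold higher number from compound 2 to compound 4 (0.30 log units; within the scatter) is expected to be modest, with its direction left open by the data.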

Compound 4, half-maximal inhibitory concentration: 12000 nM
Estimate against measurement, compound 4: 8.3-fold (0.92 log units) above, and the stated range ends above it.
By their numbers in this assay, from the lowest: compounds 4 and 1 (each within the scatter of the next); then compounds 2 and 3 (each within the scatter of the next).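

In this assay, among the compounds shown here, the urea chain changes for the first time, and the result is a 4.2-fold lower number from compound 2 to compound 4 (0.62 log units; beyond the scatter) with the 4-hydroxyphenoxy group on the sulfonyl sulfur held fixed. This shows that the chain is not a silent position: going from 3-chloropropyl to ethyl moves the number beyond the scatter, and towards stronger inhibition. The chlorine-bearing chain is therefore not required for this level of cytotoxicity in this pair, and nothing at hand gives a reason for the shift.

This single pair removes the chlorine and shortens the chain together, and it does not tell which of the two counts. On these data alone, whether a propyl group, a longer chain or an amine in place of the chlorine would move the number the same way stays open, as does whether the step would hold with 2-ethylphenyl on the oxygen.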